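A few compounds are considered here, and "the series" means these few. Any claim that something is new, unique, unknown or untested is made for them only; others in the source may bear on it.

Measured so far in an assay on COS-7 cells for agonist activity at Free fatty acid receptor 1 (Homo sapiens), read by scintillation counting and inositol phosphate accumulation, with a stated time of 90 min; on this read-out lower numbers stand for an effect already at smaller amounts and higher numbers for an effect only at larger amounts of compound:
compound 1 `Cc1ccc(Nc2nc(N)nc(COc3cc(F)cc(N4CCCC4=O)c3)n2)cc1Cl`: 1800 nM
compound 2 `Cc1ccc(Nc2nc(N)nc(COc3cc(Cl)cc(N4CCCC4=O)c3)n2)cc1Cl`: 160 nM

Within the data shown here, compound 2 gives the lowest number of the two, with compound 1 an 11-fold lower number from compound 1 to compound 2 (1.05 log units; beyond the scatter) as the only comparison. Compound 3 `Cc1cc(OCc2nc(N)nc(Nc3ccc(C)c(Cl)c3)n2)cc(N2CCCC2=O)c1` differs from compound 2 by methyl in place of chloro on an aromatic carbon. Among the measured compounds shown here, the one step that bears on this position, chloro for fluoro, is an 11-fold lower number from compound 1 to compound 2 (1.05 log units; beyond the scatter) step, so the substituent here matters; a methyl of the same size as chloro is expected to land near compound 2, a 1.6-fold higher number from compound 2 to compound 3 (0.19 log units; within the scatter). Compound 3 is therefore estimated at 250 nM, range 80 nM to 800 nM.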

Compound 3, half-maximal effective concentration: 20 nM
Beside the measured number, compound 3's estimate is 13-fold (1.10 log units) above it; the whole stated range lies above it.
By their numbers in this assay, from the lowest: compound 3; then compound 2; then compound 1.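

At this aromatic carbon, meta to a 2-oxopyrrolidin-1-yl group, methyl and chloro are not interchangeable in this assay and the swap gives an 8.0-fold lower number from compound 2 to compound 3 (0.90 log units; beyond the scatter) beyond what chloro for fluoro alone suggested. The full span at this one carbon reaches a 90-fold lower number from compound 1 to compound 3 (1.95 log units; beyond the scatter) and places methyl lowest, then chloro, then fluoro. No measurement at hand accounts for this order.

On these data alone, whether ethyl, methoxy or trifluoromethyl at this carbon would go lower than methyl stays open. Also open, as far as these compounds go, is whether the methyl gain holds when an amine replaces the 2-oxopyrrolidin-1-yl group.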